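A few compounds are considered here, and "the series" means these few. Any claim that something is new, unique, unknown or untested is made for them only; others in the source may bear on it.

In an in vitro ADME assay on microsomes from liver (Homo sapiens) for metabolic stability (a higher number here means faster removal of the compound, a lower number slower removal), compound 1 (`O=C(COCc1ccccc1)N1CCN(c2ccc(Cl)cc2)CC1`) gives 290 mL.min-1.g-1, while compound 3 (`O=C(COCc1ccncc1)N1CCN(c2ccc(Cl)cc2)CC1`) gives 17 mL.min-1.g-1, the lower of the two numbers. These two compounds differ by pyridin-4-yl in place of phenyl, and the measured change is a 17-fold lower number from compound 1 to compound 3 (1.23 log units; beyond the scatter). Compound 2 (`O=C(COCc1ccccc1)N1CCN(c2ccncc2)CC1`) offers no comparison, as its result reads "not determined" (no result reported).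

Compound 4 (`Cc1cc(Cl)ccc1N1CCN(C(=O)COCc2ccncc2)CC1`) keeps the pyridin-4-yl of compound 3 and carries methyl in place of hydrogen on an aromatic carbon, taking 4-chlorophenyl to 4-chloro-2-methylphenyl: methyl in place of hydrogen on an aromatic carbon. For the measured compounds named here, the one measured step lies at a different place in the molecule and concerns a different group, so it sets no size for this change. Going by the values given here, the data hold no measured step for such a methyl. Only a small rise in this assay is therefore expected, starting from compound 3 at 17 mL.min-1.g-1. The expected change is a 1.5-fold higher number from compound 3 to compound 4 (0.17 log units; within the scatter), an estimate that stays within the scatter. Compound 4 is estimated at 25 mL.min-1.g-1, with an expected range from 10 mL.min-1.g-1 to 65 mL.min-1.g-1.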

Compound 4, intrinsic clearance in microsomes: 68 mL.min-1.g-1
Beside the measured number, compound 4's estimate is 2.7-fold (0.43 log units) below it; measured number outside the range, above it.
By their numbers in this assay, from the lowest: compound 3; then compound 4; then compound 1.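

In this assay, methyl in place of hydrogen on an aromatic carbon gives a 4.0-fold higher number from compound 3 to compound 4 (0.60 log units; beyond the scatter), which shows that adding this single carbon, ortho to a large group and meta to a chloro group, moves the number beyond the scatter. For the compounds shown here, this is the first measured step at this position, and its direction is opposite to that of a 17-fold lower number from compound 1 to compound 3 (1.23 log units; beyond the scatter), although it is modest where that step is large. Nothing available bears on the reason for this rise.

The compounds shown leave open whether a different group on the same aromatic carbon, such as fluoro, methoxy or ethyl, would move the number as far. Going by these compounds, whether methyl would give a step of similar size with phenyl in place of pyridin-4-yl also remains open.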